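Enlarging the Group on the Aromatic Nitrogen

This account rests on a few compounds, and the source may have more. Where it says the series, first, only, none or still open, it means among the compounds named here.

compound 1 `CC(C)c1onc(-c2c(Cl)cccc2Cl)c1COc1ccc(-c2nc3ccc(C(=O)O)cc3n2C)cc1` — 7150 nM
compound 2 `CC(C)Cn1c(-c2ccc(OCc3c(-c4c(Cl)cccc4Cl)noc3C(C)C)cc2)nc2ccc(C(=O)O)cc21` — 1180 nM

Of the compounds shown here, two have been measured in an assay on HEK-293T cells for antagonist activity at vitamin D3 receptor (Homo sapiens), read by a luciferase reporter, with a stated time of 24 h; on this read-out lower numbers stand for stronger inhibition and higher numbers for weaker inhibition. Compound 1 `CC(C)c1onc(-c2c(Cl)cccc2Cl)c1COc1ccc(-c2nc3ccc(C(=O)O)cc3n2C)cc1` gives 7150 nM in this assay, and compound 2 `CC(C)Cn1c(-c2ccc(OCc3c(-c4c(Cl)cccc4Cl)noc3C(C)C)cc2)nc2ccc(C(=O)O)cc21` gives 1180 nM. The two differ in one place only, and the step of a 6.1-fold lower number from compound 1 to compound 2 (0.78 log units; beyond the scatter) is a clear one. Compound 2 therefore holds the lowest of the two numbers, with compound 1 as its nearest neighbour at the higher value.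

Compound 3 `CC(C)c1onc(-c2c(Cl)cccc2Cl)c1COc1ccc(-c2nc3ccc(C(=O)O)cc3n2C2CCCCCC2)cc1` has not yet been measured in this assay. It differs from compound 2 by cycloheptyl in place of isobutyl on an aromatic nitrogen. Going by the values given here, the only measured step that bears on this change is the one from compound 1 to compound 2, which also enlarged the group on that nitrogen and lowered the number in this assay. A further enlargement is expected to move in the same direction, though likely by a smaller margin, as the estimate a 2.0-fold lower number from compound 2 to compound 3 (0.29 log units; within the scatter) for compound 3 expresses. Compound 3 is thus estimated at 600 nM in this assay, with a range from 150 nM to 2500 nM.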

Compound 3, half-maximal inhibitory concentration: 921 nM
Compound 3: the middle estimate sits 1.5-fold (0.19 log units) below what was measured; the measured number falls inside the stated range.
By their numbers in this assay, from the lowest: compounds 3 and 2 (each within the scatter of the next); then compound 1.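

In this assay the change from isobutyl to cycloheptyl on the aromatic nitrogen gives a 1.3-fold lower number from compound 2 to compound 3 (0.11 log units; within the scatter) and so stays within the scatter: on this evidence, the ring of seven carbons and the branched chain of four carbons cannot be told apart at this position. The drop seen on leaving methyl therefore did not continue with the further enlargement from isobutyl to cycloheptyl, although the distance from the smallest group remains clear, with a 7.8-fold lower number from compound 1 to compound 3 (0.89 log units; beyond the scatter) lying beyond the scatter. Nothing shown here accounts for this result.

Going by these compounds, what remains open is whether other groups on this nitrogen, such as cyclopentyl, benzyl or a longer straight chain, would give numbers like those of compound 2 and compound 3 or would move away from them. On these data alone, it is also open whether a chain carrying an amine or a hydroxyl group would keep the number reached with these two carbon-only groups, and whether the same pattern would hold if the carboxylic acid of the shared core were replaced by an amide.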